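The compounds below may be only part of what the source reports. "The series", "measured", "known", "first", "only" and "open" are said of these compounds alone.

Measured so far:
- compound 1, `N=C(N)NCCC[C@H](N)C(=O)NS(=O)(=O)OC[C@H]1OC[C@@H](n2cnc3c(N)ncnc32)C[C@@H]1O`, 600 nM in a functional assay on PBMC cells (Homo sapiens) for inhibition; a lower number here means a stronger inhibitor, a higher number a weaker inhibitor
- compound 2, `Nc1ncnc2c1ncn2[C@@H]1CO[C@H](COS(=O)(=O)NC(=O)[C@@H]2CCCN2)[C@@H](O)C1`, 2800 nM in this assay
- compound 3, `CSCC[C@H](N)C(=O)NS(=O)(=O)OC[C@H]1OC[C@@H](n2cnc3c(N)ncnc32)[C@H](O)[C@@H]1O`, 5200 nM in this assay

Compound 3 gives the highest of the three numbers in this assay; its gap to compound 2 is within the scatter, while compound 1 sits well below it, beyond the scatter. Among the compounds with values here, the only measured step changes the amino-acid part on the carbonyl carbon, and it was of modest size: a 4.7-fold higher number from compound 1 to compound 2 (0.67 log units; beyond the scatter). This shows that the group on the carbonyl carbon can shift the number, but it does not involve the groups exchanged here.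

Compound 4, `CC(C)C[C@H](N)C(=O)NS(=O)(=O)OC[C@H]1OC[C@@H](n2cnc3c(N)ncnc32)[C@H](O)[C@@H]1O`, differs from compound 3 in one place: isopropyl in place of (methylsulfanyl)methyl on a saturated chain carbon, two bonds along the chain from an amine nitrogen and a carbonyl carbon. Within the data shown here, no measured pair shows this exchange, so the direction is open; a change of modest size or none beyond the scatter is expected. Compound 4 is therefore estimated at 4000 nM, with a range from 1000 nM to 15000 nM, meaning an expected step of a 1.3-fold lower number from compound 3 to compound 4 (0.11 log units; within the scatter).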

Compound 4, half-maximal inhibitory concentration: 1000 nM
The estimate for compound 4 lay 4.0-fold (0.60 log units) above the measured number, within the range that was stated.
By their numbers in this assay, from the lowest: compounds 1 and 4 (each within the scatter of the next); then compounds 2 and 3 (each within the scatter of the next).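

In this assay, the saturated chain carbon, two bonds along the chain from an amine nitrogen and a carbonyl carbon, responds to the group it carries: isopropyl in place of (methylsulfanyl)methyl gives a 5.2-fold lower number from compound 3 to compound 4 (0.72 log units; beyond the scatter). The number moves beyond the scatter even though the count of heavy atoms stays the same, while sulfur and a hydrogen-bond acceptor leave and a branched all-carbon group enters. Nothing measured alongside this result explains the step, so it records a change in the number and not its cause.

This single pair cannot separate the loss of sulfur from the gain of branching, and an unbranched propyl group at this place would be needed to tell them apart. From the compounds shown here alone, how the number responds to an amine or a carboxylic acid at this place also remains open.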